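The compounds below may be only part of what the source reports. "The series", "measured", "known", "first", "only" and "open" are said of these compounds alone.

Compound 1 `CON(C)C(=O)C1(S(=O)(=O)c2ccc(Oc3ccc(OC(F)(F)F)cc3)cc2)CCC2(CCNCC2)C1` gives 3700 nM in a functional assay on blood (Homo sapiens), with a stated time of 60 min, in the presence of a further agent that is not named here; on this read-out higher numbers stand for an effect only at larger amounts of compound and lower numbers for an effect already at smaller amounts.
Compound 2 `O=S(=O)(c1ccc(Oc2ccc(OC(F)(F)F)cc2)cc1)C1CCC2(CCNCC2)C1` gives > 15000 nM.
Compound 3 `O=C(O)C1(S(=O)(=O)c2ccc(Oc3ccc(OC(F)(F)F)cc3)cc2)CCC2(CCNCC2)C1` gives 1800 nM.

The value of compound 2 is a limit of this assay and not a number (the limit of > 15000 nM in this assay, at which 1 of the 3 values shown sits). Among the two numbers shown, compound 3 stands lowest; compound 1 is its nearest neighbour, with a 2.1-fold lower number from compound 1 to compound 3 (0.31 log units; beyond the scatter). The move from compound 3 to compound 4 `O=C(Oc1ccccc1)C1(S(=O)(=O)c2ccc(Oc3ccc(OC(F)(F)F)cc3)cc2)CCC2(CCNCC2)C1` is phenyl in place of hydrogen on an oxygen next to a carbonyl group. For the measured compounds named here, two measured steps bear on it. Taking the group off the saturated ring carbon altogether gave an at least 8.3-fold lower number from compound 2 to compound 3 (0.92 log units; beyond the scatter), so the carboxy contributes strongly. Swapping hydroxy for methoxy(methyl)amino on the carbonyl carbon gave a 2.1-fold lower number from compound 1 to compound 3 (0.31 log units; beyond the scatter), a modest cost. Compound 4 keeps the carbonyl but gives up hydroxy for phenoxy, so a modest rise in the number, beyond the scatter, is expected, a 2.8-fold higher number from compound 3 to compound 4 (0.44 log units; beyond the scatter). Compound 4 is estimated at 5000 nM in this assay, with a range from 1500 nM to 18000 nM.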

Compound 4, half-maximal effective concentration: 900 nM
Estimate against measurement, compound 4: 5.6-fold (0.74 log units) above, and the stated range ends above it.
By their numbers in this assay, from the lowest: compounds 4 and 3 (each within the scatter of the next); then compound 1. At a limit, above all of these: compound 2.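

In this assay, putting phenoxy in place of hydroxy on the carbonyl carbon does not separate the two compounds, with a 2.0-fold lower number from compound 3 to compound 4 (0.30 log units; within the scatter), so a free carboxy is not needed at this saturated ring carbon for a number of this size, and the added six-membered aromatic ring is accommodated. Phenoxy also stands clear of methoxy(methyl)amino on the same carbonyl carbon, with a 4.1-fold lower number from compound 1 to compound 4 (0.61 log units; beyond the scatter), and phenoxycarbonyl stands clear of hydrogen on the ring carbon, with an at least 16-fold lower number from compound 2 to compound 4 (1.22 log units; beyond the scatter), which shows that the gain from a carbonyl-bearing group at this position extends to phenoxycarbonyl. The value of compound 2 in that last step is a limit and not a number: the limit of > 15000 nM in this assay, at which 1 of the 4 values shown sits.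

What the compounds shown leave open is whether a methyl group or a longer chain on this oxygen would serve as well as phenyl. Also open, from the compounds shown here alone, is how a simple amine on the carbonyl carbon, or a fluorine on the phenyl ring, would read.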